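Replacing the tert-butylamino group of compound 1

The source may report more compounds than this note shows. Statements on the series, on what has been measured and on what is new or still open speak of the compounds shown alone.

Compound 1 `C[C@H](Nc1nc(Cl)nc(NC(C)(C)C)n1)c1ccccc1` has the lowest number of the three measured compounds in an ADME assay on the whole organism for inhibition, with Oryza sativa as the target, with a stated time of 4 days (on this read-out lower numbers stand for stronger inhibition and higher numbers for weaker inhibition), at 3310 nM. Compound 3 `C[C@@H](Nc1nc(Cl)nc(NC(C)(C)C)n1)c1ccccc1` gives 9330 nM, and compound 2 `CNc1nc(Cl)nc(N[C@H](C)c2ccccc2)n1` gives 22400 nM. Compound 4 `CCCN(CCC)c1nc(Cl)nc(N[C@@H](C)c2ccccc2)n1` keeps the configuration of compound 1 as drawn and changes in one place: dipropylamino in place of (tert-butyl)amino on an aromatic carbon.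

For the measured compounds named here, two measured steps bear on this change. The only one that alters this amino substituent is a 2.4-fold lower number from compound 2 to compound 3 (0.38 log units; beyond the scatter), where tert-butyl stands in place of methyl on a nitrogen. The other, a 2.8-fold higher number from compound 1 to compound 3 (0.45 log units; beyond the scatter), goes with the fact that compounds 1 and 3 differ only in the configuration as drawn, and that difference does not arise here. It shows only how large a single change can be in this small set. Going by the values given here, no measured compound carries dipropylamino, so the transfer is loose. Since compound 2 lost ground without tert-butyl, at 22400 nM, a higher number is expected in this assay. The expected step is a 3.3-fold higher number from compound 1 to compound 4 (0.52 log units; beyond the scatter). For compound 4 the estimated value is 11000 nM, with an expected range of 3500 nM to 35000 nM.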

Compound 4, half-maximal inhibitory concentration: 331 nM
Estimate against measurement, compound 4: 33-fold (1.52 log units) above; measured number outside the range, below it.
By their numbers in this assay, from the lowest: compound 4; then compound 1; then compound 3; then compound 2.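

In this assay, dipropylamino in place of (tert-butyl)amino on this aromatic carbon gives a 10-fold lower number from compound 1 to compound 4 (1.00 log units; beyond the scatter) and so reverses the direction suggested by the step between methyl and tert-butyl, showing that this position can carry a group with more heavy atoms and no hydrogen-bond donor and still give a lower number than compound 1. For the compounds shown here, this is also the largest single step so far, so the amino substituent here has a stronger link to the read-out than the earlier compounds indicated. Nothing available on these compounds explains the step.

The compounds shown do not separate the effect of the two propyl chains from that of losing the amino hydrogen, a question that propylamino with its single chain would address. Diethylamino, dibutylamino and a ring amine such as piperidine would show how far the trend extends, and the opposite configuration of compound 4 remains open too.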